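Compound 4: Bromine Moved, Tolerance Not Yet Known

The source may hold more compounds than are shown below. What is called first, only, known or untested is meant among the compounds shown, and "the series" means these compounds.

Compound 1 `FC(F)(F)c1cccc(NC(=S)Nc2cccc(Br)c2)c1` was tested in an ADME assay on MT4 cells (Homo sapiens) for cytotoxicity (a higher number here means that more compound is tolerated, a lower number that less compound is tolerated), where compound 1 gives 9200 nM. Among the three compounds measured there, compound 1 stands second highest. Compound 3 `Fc1ccc(NC(=S)Nc2cccc(C(F)(F)F)c2)cc1Cl` gives 8000 nM, a number within the usual scatter of that for compound 1, so the two cannot be told apart. Compound 2 `COc1cccc(NC(=S)Nc2cccc(C(F)(F)F)c2)c1` gives 26000 nM. For the measured compounds named here, the only measured step is a 2.8-fold higher number from compound 1 to compound 2 (0.45 log units; beyond the scatter), brought about by a methoxy in place of bromo on an aromatic carbon.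

Compound 4 `FC(F)(F)c1cccc(NC(=S)Nc2ccccc2Br)c1` has not yet been measured. It differs from compound 1 by 2-bromophenyl in place of 3-bromophenyl on an amide-type nitrogen. Going by the values given here, no measured step compares a 2-bromophenyl with a 3-bromophenyl: the single known step replaces the bromo group altogether, so it does not speak to this change. Among the compounds with values here, with nothing among the measured compounds to indicate a direction, the expected step is a 1.0-fold lower number from compound 1 to compound 4 (0.01 log units; within the scatter), none beyond the scatter. Compound 4 is therefore estimated at 9000 nM in this assay, with a range from 4000 nM to 20000 nM.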

Compound 4, half-maximal cytotoxic concentration: 36000 nM
Beside the measured number, compound 4's estimate is 4.0-fold (0.60 log units) below it; the whole stated range lies below it.
By their numbers in this assay, from the lowest: compounds 3 and 1 (each within the scatter of the next); then compounds 2 and 4 (each within the scatter of the next).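

In this assay, the bromine does not have to be replaced for the number to move: 2-bromophenyl in place of 3-bromophenyl on an amide-type nitrogen gives a 3.9-fold higher number from compound 1 to compound 4 (0.59 log units; beyond the scatter) with the atoms themselves unchanged. For the compounds shown here, until now, the only step read at this group was the swap of bromo for methoxy, so this is the first sign that where the bromine sits on the phenyl ring counts by itself. No measured evidence bears on why the number moves with this change.

The compounds shown leave open whether methoxy in place of the bromo of compound 4 would move the number as it did from compound 1, and whether bromine is needed at all. An amine or a carboxylic acid at that spot would test how far the higher number holds.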